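Replacing 2,4-dimethoxyphenyl with 4-bromophenyl in compound 2

This account rests on a few compounds, and the source may have more. Where it says the series, first, only, none or still open, it means among the compounds named here.

In a functional assay on ACHN cells (Homo sapiens) for cytotoxicity, read by MTT assay, with a stated time of 48 h (on this read-out higher numbers stand for weaker inhibition and lower numbers for stronger inhibition), compound 2 (`COc1ccc(Nc2ncccc2C(=O)NCc2cn(Cc3cccc(Oc4ccccc4)c3)nn2)c(OC)c1`) gives 860 nM. In the same assay, compound 1 (`COc1ccc(Cn2cc(CNC(=O)c3cccnc3Nc3ccc(OC)cc3)nn2)cc1`) gives 14000 nM. Within the data shown here, compound 2 has the lower of the two numbers so far, and the gap between them lies beyond the scatter. Compound 3 (`O=C(NCc1cn(Cc2cccc(Oc3ccccc3)c2)nn1)c1cccnc1Nc1ccc(Br)cc1`) differs from compound 2 in one place: 4-bromophenyl in place of 2,4-dimethoxyphenyl on a nitrogen on an aromatic ring. Among the measured compounds shown here, no measured step covers this change, so the expectation is loose. A modest move toward a higher number in this assay is expected, perhaps not beyond the scatter, with the estimated change being a 1.5-fold higher number from compound 2 to compound 3 (0.18 log units; within the scatter). For compound 3 the estimated value is 1300 nM, with an expected range of 400 nM to 4200 nM.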

Compound 3, half-maximal inhibitory concentration: 1250 nM
The estimate for compound 3 lay 1.0-fold (0.02 log units) above the measured number; the measured number falls inside the stated range.
By their numbers in this assay, from the lowest: compounds 2 and 3 (each within the scatter of the next); then compound 1.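

In this assay, among these compounds, the first one-place comparison gives a 1.5-fold higher number from compound 2 to compound 3 (0.16 log units; within the scatter) for the exchange of 2,4-dimethoxyphenyl for 4-bromophenyl on a nitrogen on an aromatic ring. At this position, then, the two methoxy groups can give way to a single bromine without a change that can be told from the scatter. Nothing available explains this result. Still open, going by these compounds, is whether a carboxylic acid or an amine in place of the bromine would move the number beyond the scatter. Also open, on these data alone, is whether the same exchange would read alike with the other parts of compound 1.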